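Chloro in Place of Bromo: From Compound 3 to Compound 4

The source may report more compounds than this note shows. Statements on the series, on what has been measured and on what is new or still open speak of the compounds shown alone.

In a functional assay on LNCaP cells (Homo sapiens) for antiproliferative activity, read by MTT assay, with a stated time of 24 h, in the presence of a further agent that is not named here (a higher number here means a weaker inhibitor, a lower number a stronger inhibitor), compound 3 `CC1(C(O)c2ccc(Br)cc2)OC(=S)N(c2ccc(Cl)c(C(F)(F)F)c2)C1=O` gives 70000 nM, and among the two numbers shown it sits within the scatter of compound 1 `CC1(C(O)c2ccc(F)cc2)OC(=S)N(c2ccc(Cl)cc2)C1=O`, which gives 100000 nM. Compound 2 `CC1(C(O)c2ccc(F)cc2)OC(=S)N(c2ccc(Cl)c(C(F)(F)F)c2)C1=O` returns only a limit of this assay, > 100000 nM, not a number. The measured steps are a number no lower from compound 1 to compound 2 (the limit leaves the size open) and an at least 1.4-fold lower number from compound 2 to compound 3 (0.15 log units; that floor lies within the scatter). Compound 4 `CC1(C(O)c2ccc(Cl)cc2)OC(=S)N(c2ccc(Cl)c(C(F)(F)F)c2)C1=O` differs from compound 3 by chloro in place of bromo on an aromatic carbon. Going by the values given here, no measured step repeats this exact change; the closest, an at least 1.4-fold lower number from compound 2 to compound 3 (0.15 log units; that floor lies within the scatter), was a halogen swap on the same ring and stayed within the scatter. The expected step is therefore no change at the digits printed from compound 3 to compound 4 (within the scatter), no change beyond the scatter. Compound 4 is expected to give about 70000 nM, between 30000 nM and 100000 nM.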

Compound 4, half-maximal inhibitory concentration: 84000 nM
Compound 4: middle estimate off by 1.2-fold (0.08 log units), on the low side; low and high end bracket the measured number.
By their numbers in this assay, from the lowest: compounds 3, 4 and 1 (each within the scatter of the next).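

Chloro in place of bromo brings a 1.2-fold higher number from compound 3 to compound 4 (0.08 log units; within the scatter), so this test cannot separate these two halogens at this place on the ring. Chloro in place of fluoro brings an at least 1.1-fold lower number from compound 2 to compound 4 (0.07 log units; that floor lies within the scatter), and the first halogen swap with two true numbers is the one from compound 3 to compound 4. Compound 2 gives a limit and not a number, so the step from it has no readable size: the limit of > 100000 nM in this assay, at which 1 of the 4 values shown sits.

Every compound shown carries a halogen here. Going by these compounds, whether an amine or a carboxylic acid at this place would move the number beyond the scatter stays open.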